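Pyrazolyl exchange from compound 3 to compound 4

This account rests on a few compounds, and the source may have more. Where it says the series, first, only, none or still open, it means among the compounds named here.

Values so far in an ADME assay on microsomes from liver (Homo sapiens) for metabolic stability (on this read-out higher numbers stand for fast clearance and lower numbers for slow clearance), are as follows.

compound 1 `CCCC(Oc1ccc(-n2cc(OC)cn2)cc1)c1ccc(C(=O)NCCC(=O)O)cc1`: < 8 mL/min/kg (a limit)
compound 2 `CCCC(Oc1ccc(-n2cc3ccccc3n2)cc1)c1ccc(C(=O)NCCC(=O)O)cc1`: 44 mL/min/kg
compound 3 `CCCC(Oc1ccc(-n2cc(C(=O)N(C)C)cn2)cc1)c1ccc(C(=O)NCCC(=O)O)cc1`: < 13 mL/min/kg (a limit)

Compound 3 gives < 13 mL/min/kg as a limit and not a number. The next change, to compound 4 `CCCC(Oc1ccc(-n2cc(C(F)(F)F)c(C)n2)cc1)c1ccc(C(=O)NCCC(=O)O)cc1`, puts 3-methyl-4-(trifluoromethyl)-1H-pyrazol-1-yl in place of 4-(dimethylcarbamoyl)-1H-pyrazol-1-yl on an aromatic carbon, para to a large group (3-methyl-4-(trifluoromethyl)-1H-pyrazol-1-yl in place of 4-(dimethylcarbamoyl)-1H-pyrazol-1-yl on an aromatic carbon).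

Within the data shown here, two measured steps bear on this change, and both lie beyond the scatter: an at least 5.5-fold higher number from compound 1 to compound 2 (0.74 log units; beyond the scatter) and an at least 3.3-fold lower number from compound 2 to compound 3 (0.52 log units; beyond the scatter) mark out the span of the set so far. A third comparison (a step that the two limits leave unreadable from compound 1 to compound 3) gives no readable size. Compound 4 keeps a 1H-pyrazol-1-yl group, as compound 1 and compound 3 do, so it is expected to stay closer to those two than to compound 2 at 44 mL/min/kg in this set of three. A small upward move is expected, though a limit is still possible. The step expected is an at least 1.2-fold higher number from compound 3 to compound 4 (0.09 log units; that floor lies within the scatter) and its size stays uncertain, since it starts from a limit. Compound 4 is estimated at 16 mL/min/kg with an expected range from 7 mL/min/kg to 36 mL/min/kg in this assay as the read-out.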

Compound 4, clearance: < 10 mL/min/kg
Compound 4 ended at the assay's limit (the forecaster's own chance of this, stated with the estimate: 35%); at least 1.6-fold (0.20 log units) between middle value and limit.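

In this assay, compound 4 gives < 10 mL/min/kg, which is a limit and not a number: the limit of < 10 mL/min/kg in this assay, at which 1 of the 4 values shown sits.

Replacing the 2H-indazol-2-yl group of compound 2 with the 3-methyl-4-(trifluoromethyl)-1H-pyrazol-1-yl group gives an at least 4.4-fold lower number from compound 2 to compound 4 (0.64 log units; beyond the scatter), so a reading beyond the scatter at this position, para to a large group, now holds for a second 1H-pyrazol-1-yl group carrying different substituents. Among these compounds, the entering group has no oxygen and no carbonyl, yet all three 1H-pyrazol-1-yl compounds, compound 1, compound 3 and compound 4, sit at limits, while compound 2 goes against that picture as the only one with a number; the steps from compound 3 and compound 1 to compound 4 join two limits and cannot be read.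

The limits differ from compound to compound and give no order among these three, so the effect of the exchange itself remains unknown. Also open, from the compounds shown here alone, is whether the 1H-pyrazol-1-yl group stays at a limit with an amine or a carboxylic acid as its substituent, or with no substituent at all.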